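Diethylamide in place of the free acid on compound 2

The source may hold more compounds than are shown below. What is called first, only, known or untested is meant among the compounds shown, and "the series" means these compounds.

Measured so far in a functional assay on the whole organism (Ear) for inhibition, with Mus musculus as the target, at a dose of 40 mg/kg by the oral route; on this read-out higher numbers stand for more inhibition at the one dose given (going by the name of the read-out) and lower numbers for less inhibition:
- compound 1 `CC(=O)Oc1ccc(-c2ccc(F)cc2F)cc1C(=O)O`: 13.7%
- compound 2 `O=C(Oc1ccc(-c2ccc(F)cc2F)cc1C(=O)O)c1ccccc1`: 16.1%
- compound 3 `CC(=O)Oc1ccc(-c2ccc(F)cc2F)cc1C(=O)Nc1cccc(C)c1`: 12.8%

Compound 2 carries the highest number of the three in this assay, but compound 1 and compound 3 both lie within the usual scatter of it, so no order among the three can be claimed. The step of a number 2.4 percentage points higher from compound 1 to compound 2 (within the scatter) and the step of a number 0.9 percentage points lower from compound 1 to compound 3 (within the scatter) are both within the scatter.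

Compound 4 `CCN(CC)C(=O)c1cc(-c2ccc(F)cc2F)ccc1OC(=O)c1ccccc1` is not yet measured. Relative to compound 2 the change is diethylamino in place of hydroxy on a carbonyl carbon. Within the data shown here, the one measured step that bears on this change is the one from compound 1 to compound 3, where the hydroxy on the same carbonyl carbon was replaced by an amino group; that step was a number 0.9 percentage points lower from compound 1 to compound 3 (within the scatter), within the scatter. On this basis the expected step for compound 4 is a number 2.1 percentage points lower from compound 2 to compound 4 (within the scatter), none beyond the scatter. The estimate for compound 4 in this assay is 14%, with a range from 5% to 24%.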

Compound 4, a percentage reported as inhibition, in the whole organism at one dose (the size of the read-out at that dose, not a potency): 65.2%
Estimate against measurement, compound 4: 51.2 percentage points below, and the stated range ends below it.
By their numbers in this assay, from the lowest: compounds 3, 1 and 2 (each within the scatter of the next); then compound 4.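

In this assay, among these compounds, the carbonyl carbon turns out to be a position where the series can respond strongly: diethylamino in place of hydroxy gives a number 49.1 percentage points higher from compound 2 to compound 4 (beyond the scatter), the only step so far beyond the scatter. The earlier replacement of hydroxy on this carbon, (3-methylphenyl)amino in the step of a number 0.9 percentage points lower from compound 1 to compound 3 (within the scatter), therefore did not show what this position can do, so replacing the hydroxy does not by itself leave the read-out unchanged. The data give no reason for the size of the new step.

Going by these compounds, because the two steps differ in both the entering group and the ester on the core, it remains open whether the gain depends on diethylamino alone or also on the benzoyl ester. Also open, on these data alone, are how dimethylamino or dipropylamino on the same carbonyl carbon would read, and whether diethylamino keeps this effect with an acetyl ester in place of the benzoyl ester.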